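Removing a chloro from a purine-based cytotoxic agent

The source may hold more compounds than are shown below. What is called first, only, known or untested is meant among the compounds shown, and "the series" means these compounds.

Measured so far:
compound 1 `ClCc1ccc(Cn2cnc3c(Cl)ncnc32)cc1` gives 5620 nM
compound 2 `ClCc1ccccc1Cn1cnc2c(Cl)nc(Cl)nc21` gives 450 nM

In a functional assay on BT-549 cells (Homo sapiens) for cytotoxicity, read by sulforhodamine B assay, with a stated time of 48 h (on this read-out higher numbers stand for weaker inhibition of growth and lower numbers for stronger inhibition of growth), compound 2 has the lowest number of the two, and the number of compound 1 lies well beyond the scatter above it. Compound 3 `ClCc1ccccc1Cn1cnc2c(Cl)ncnc21` differs from compound 2 in one place: hydrogen in place of chloro on an aromatic carbon. Without a comparable measured pair, the step from compound 2 to compound 3 is expected to weaken growth inhibition by a moderate amount, with a 3.3-fold higher number from compound 2 to compound 3 (0.52 log units; beyond the scatter) as the expected size. Compound 3 is estimated at 1500 nM, within 500 nM to 5000 nM.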

Compound 3, concentration for 50% growth inhibition: 1990 nM
Compound 3: the middle estimate sits 1.3-fold (0.12 log units) below what was measured, within the range that was stated.
By their numbers in this assay, from the lowest: compound 2; then compound 3; then compound 1.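

In this assay, the chloro on the aromatic carbon between two ring nitrogen atoms matters: replacing it with hydrogen gives a 4.4-fold higher number from compound 2 to compound 3 (0.65 log units; beyond the scatter), a modest loss of growth inhibition. This position therefore affects the read-out, yet the chloro there is not essential, since compound 3 still gives 1990 nM. No available data explain this step.

On these data alone, whether an amine or a methoxy group at this position would match the chloro of compound 2 or fall nearer to the hydrogen of compound 3 remains open.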